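This account rests on a few compounds, and the source may have more. Where it says the series, first, only, none or still open, it means among the compounds named here.

Measured in a functional assay on MCF7 cells (Homo sapiens) for inhibition, read by sulforhodamine B assay, with a stated time of 48 h; on this read-out lower numbers stand for stronger inhibition of growth and higher numbers for weaker inhibition of growth:
compound 1 `O=C1C=COC(/C=C/c2ccc(C(F)(F)F)cc2)C1` gives 41.2 uM
compound 2 `COc1ccc(C2CC(=O)C=CO2)cc1` gives 173 uM
compound 3 `COc1ccc(C2CC(=O)C(Br)=CO2)cc1` gives 42.2 uM

Compound 3 sits close to compound 1, the two numbers lying within the scatter of each other, while compound 2 stands apart: a 4.1-fold lower number from compound 2 to compound 3 (0.61 log units; beyond the scatter). Compound 4 `COc1ccc(C2CC(=O)C(I)=CO2)cc1` is the next compound, and it differs from compound 3 in one place: iodo in place of bromo on a double-bonded ring carbon. Among the measured compounds shown here, the only measured step concerns a bromine added in place of a hydrogen, not one halogen swapped for another, so no measured step bears directly on this change. With nothing pointing either way, the step from compound 3 to compound 4 is expected to stay small, and a 1.2-fold lower number from compound 3 to compound 4 (0.07 log units; within the scatter) is the expected step, within the scatter. Compound 4 is therefore estimated at 36 uM, with a range from 15 uM to 90 uM.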

Compound 4, concentration for growth inhibition (reported as GI): 43.2 uM
Beside the measured number, compound 4's estimate is 1.2-fold (0.08 log units) below it; the range from low to high includes it.
By their numbers in this assay, from the lowest: compounds 1, 3 and 4 (each within the scatter of the next); then compound 2.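

Swapping bromo for iodo on this double-bonded ring carbon gives a 1.0-fold higher number from compound 3 to compound 4 (0.01 log units; within the scatter) in this assay, so the two halogens cannot be told apart here. Iodo in place of hydrogen gives a 4.0-fold lower number from compound 2 to compound 4 (0.60 log units; beyond the scatter), which shows that the stronger growth inhibition seen with bromine also appears with a second halogen. Nothing available explains this result.

Still open, on these data alone, is whether a smaller halogen such as chloro, or a non-halogen such as methyl or nitrile, at this carbon would do the same. Also open, as far as these compounds go, is whether bromo or iodo would act alike on the core of compound 1.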